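From propyl to cyclopropyl on a shared core

The compounds below may be only part of what the source reports. "The series", "measured", "known", "first", "only" and "open" are said of these compounds alone.

In an ADME assay on CEMx174 cells (Homo sapiens) for cytotoxicity (on this read-out higher numbers stand for lower toxicity in this test and lower numbers for higher toxicity in this test), compound 1 (`CC1=C(C(=O)NCC2CCCCC2)C(c2cccc(O)c2)NC(=O)N1`) gives "not determined" (no result reported) and so offers no guidance. Compound 2 (`CCC1=C(C(=O)OCC2CCCCC2)C(c2cccc(O)c2)NC(=O)N1`) gives > 10000 nM and this is a limit of the assay, not a number. Compound 3 (`CCCC1=C(C(=O)OCC2CCCCC2)C(c2cccc(O)c2)NC(=O)N1`) gives > 10000 nM and this too is only a limit. Compound 3 thus stands at the limit of > 10000 nM in this assay, at which 2 of the 3 values shown sit, with no exact number of its own.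

Compound 4 (`O=C1NC(C2CC2)=C(C(=O)OCC2CCCCC2)C(c2cccc(O)c2)N1`) carries cyclopropyl in place of propyl on a double-bonded ring carbon, and cyclopropyl in place of propyl on a double-bonded ring carbon sets out the swap in full. Going by the values given here, the only measured step that bears on this change is a step that the two limits leave unreadable from compound 2 to compound 3 and it has no readable size. In this assay no shift beyond the usual scatter is therefore expected, in either direction. The estimated step is a step that the limit leaves unreadable from compound 3 to compound 4 and it should be read as an expectation only. For compound 4 the expected value is 20000 nM with an estimated range from 8000 nM to 50000 nM and the result may well arrive as another limit.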

Compound 4, half-maximal cytotoxic concentration: > 10000 nM
Compound 4: a limit, no number; the forecaster's own chance of this, stated with the estimate: 85%; the middle value lies beyond the limit too.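

No step among compound 2, compound 3 and compound 4 can be read, as each gives only a limit and not a number: the limit of > 10000 nM in this assay, at which 3 of the 4 values shown sit.

The compounds shown leave open whether ethyl, propyl and cyclopropyl differ at all in this read-out, and at what concentration any of the three harms these cells.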